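From compound 1 to compound 4: one ring exchanged

The source may hold more compounds than are shown below. What is called first, only, known or untested is meant among the compounds shown, and "the series" means these compounds.

In an ADME assay on the whole organism (Mus musculus, strain BALB/c) for metabolic stability, read by LC-MS, with a stated time of 24 h, at a dose of 1 mg/kg by the intravenous route (a higher number here means that the compound lasts longer, a lower number that the compound disappears faster), compound 1 `Cn1nccc1-c1cc(C(F)(F)F)ccc1[C@H]1CCOc2cc(S(=O)(=O)Nc3nccs3)ccc21` reads 2 h while compound 2 `Cn1nccc1-c1cc(C(F)(F)F)ccc1[C@H]1CCOc2cc(S(=O)(=O)Nc3ncccn3)ccc21` reads 4.2 h and compound 3 `Cn1nccc1-c1cc(C(F)(F)F)ccc1[C@H]1CCc2cc(S(=O)(=O)Nc3ncccn3)ccc21` reads 2.8 h on the same scale. Compound 1 sits within the scatter of compound 3 and beyond the scatter from compound 2. Compound 4 `O=S(=O)(Nc1nccs1)c1ccc2c(c1)OCC[C@@H]2c1ccc(C(F)(F)F)cc1-n1ccnn1` keeps the 1,3-thiazol-2-yl group on the sulfonamide nitrogen and the core of compound 1, and it differs in one place: 1H-1,2,3-triazol-1-yl in place of 1-methyl-1H-pyrazol-5-yl on an aromatic carbon in this exchange. The new ring stands on an aromatic carbon, ortho to a large group and meta to a trifluoromethyl group. Among the measured compounds shown here, the only measured single-place step, a 2.1-fold higher number from compound 1 to compound 2 (0.32 log units; beyond the scatter) at the sulfonamide nitrogen, is modest and lies elsewhere in the structure. No measurement therefore bears directly on this exchange. The estimated step is no change at the digits printed from compound 1 to compound 4 (within the scatter) and no change beyond the scatter is expected, with neither direction favoured. For compound 4 the expected half-life is 2 h with an estimated range from 0.9 h to 4.5 h for repeated measurements.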

Compound 4, half-life: 0.4 h
Compound 4: the middle estimate sits 5.0-fold (0.70 log units) above what was measured; the whole stated range lies above it.
By their numbers in this assay, from the lowest: compound 4; then compounds 1, 3 and 2 (each within the scatter of the next, the first and the last beyond it).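

In this assay the exchange of 1-methyl-1H-pyrazol-5-yl for 1H-1,2,3-triazol-1-yl gives a 5.0-fold lower number from compound 1 to compound 4 (0.70 log units; beyond the scatter) and so shows that the ring on this aromatic carbon, ortho to a large group and meta to a trifluoromethyl group, can move the half-life beyond the scatter. Among the compounds shown here, until now the only single-place step was at the sulfonamide nitrogen, and that step, a 2.1-fold higher number from compound 1 to compound 2 (0.32 log units; beyond the scatter), runs the other way. Nothing measured here explains why the triazole ring gives the shorter half-life.

The compounds shown leave open whether the same exchange lowers the number when pyrimidin-2-yl stands on the sulfonamide nitrogen, as in compound 2. They also leave open how the half-life responds when a phenyl ring or a nitrile stands on this aromatic carbon.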